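The compounds below may be only part of what the source reports. "The series", "measured", "known", "first", "only" and "open" are said of these compounds alone.

Working notes on the series. For the measured compounds named here, the shared core is the one seen in compound 1 `Cc1cc(=O)oc2cc(Sc3cccc(Cl)n3)ccc12`, where a chloropyridinyl group sits directly on the sulfur. In a functional assay on KB cells (Homo sapiens) for antiproliferative activity, read by sulforhodamine B assay, with a stated time of 72 h (on this read-out higher numbers stand for weaker inhibition of growth and lower numbers for stronger inhibition of growth), compound 1 gives 920 nM. Compound 2 `Cc1cc(=O)oc2cc(SCc3cccc(C(F)(F)F)c3)ccc12` instead carries a benzyl group on the sulfur, with a trifluoromethyl on the benzene ring. In this assay compound 2 gives only > 28500 nM, which is a limit of the assay and not a number. Going by the values given here, compound 2 therefore stands at the weak end of the two results seen, as noted in the limit of > 28500 nM in this assay, at which 1 of the 2 values shown sits, while compound 1 sits at a measured value; no step between the two is computed here, since they differ in more than one place.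

Compound 3 `COC(=O)c1cccc(CSc2ccc3c(C)cc(=O)oc3c2)c1` keeps the benzyl thioether of compound 2 and changes one group: methoxycarbonyl in place of trifluoromethyl on an aromatic carbon, meta to a large group. Among the compounds with values here, no measured step of this kind exists, so the expectation rests on compound 2 alone. Compound 3 is expected to stay near the weak end, with the step from compound 2 to compound 3 estimated as an at least 1.1-fold lower number from compound 2 to compound 3 (0.05 log units; that floor lies within the scatter), and a fair chance that only a limit is reported again. Compound 3 is estimated at 25000 nM, within a range from 6000 nM to 80000 nM.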

Compound 3, concentration for 50% growth inhibition: 2060 nM
For compound 3 the middle estimate is 12-fold (1.08 log units) above the measured one; measured number below the stated range.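

In this assay the aromatic carbon meta to a large group on the benzyl ring responds clearly to substitution: methoxycarbonyl in place of trifluoromethyl gives an at least 13-fold lower number from compound 2 to compound 3 (1.14 log units; beyond the scatter), the first step read at this position. A benzyl group on the sulfur is also no bar to a measured value in this series, as compound 3 carries one and gives 2060 nM. Compound 2 is known only through a limit of the assay, which is not a number, so the step stands as a floor and its full size remains unread: the limit of > 28500 nM in this assay, at which 1 of the 3 values shown sits.

With a single change at this position, the compounds shown leave open whether the result is particular to methoxycarbonyl or would also be seen with a carboxylic acid, a primary amide or a nitrile on the same aromatic carbon. They also leave open what the methylene link of the benzyl thioether contributes, as compound 1 differs from compound 3 in more than one place and a methoxycarbonyl group on a ring attached directly to the sulfur would be needed to separate the two.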